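Quinone analogue with sulfamoyl on the N-aryl ring

A few compounds are considered here, and "the series" means these few. Any claim that something is new, unique, unknown or untested is made for them only; others in the source may bear on it.

Measured compounds:
compound 1 `NS(=O)(=O)c1ccc(-n2nc(-c3ccc(Cl)cc3)cc2-c2cc(O)ccc2O)cc1` — 61400 nM
compound 2 `O=C1C=CC(=O)C(c2cc(-c3ccc(Cl)cc3)nn2-c2ccccc2)=C1` — 87100 nM

In a functional assay on cells (Leukemia cell, Homo sapiens) for cytotoxicity, read by sulforhodamine B assay, with a stated time of 48 h (a lower number here means a stronger inhibitor of growth, a higher number a weaker inhibitor of growth), compound 1 gives 61400 nM. In this assay compound 2 gives 87100 nM. The two values sit within the usual scatter of one another, so neither can be set apart from the other, and compound 2 stands level with compound 1 on the numbers in hand. Among the compounds with values here, the two structures differ at more than one place, so no single step between them can be read.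

Compound 3 `NS(=O)(=O)c1ccc(-n2nc(-c3ccc(Cl)cc3)cc2C2=CC(=O)C=CC2=O)cc1` is not yet measured. It differs from compound 2 by sulfamoyl in place of hydrogen on an aromatic carbon. Within the data shown here, no measured pair isolates this change. With compound 1 carrying the same sulfamoylphenyl group and giving 61400 nM, no move beyond the scatter is expected; the step of a 1.3-fold lower number from compound 2 to compound 3 (0.13 log units; within the scatter) is estimated to be small. Compound 3 is expected at 65000 nM, within 25000 nM to 160000 nM.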

Compound 3, concentration for total growth inhibition: 84600 nM
Estimate against measurement, compound 3: 1.3-fold (0.11 log units) below; the range from low to high includes it.
By their numbers in this assay, from the lowest: compounds 1, 3 and 2 (each within the scatter of the next).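

In this assay, within the data shown here, phenyl to 4-sulfamoylphenyl, with sulfamoyl on an aromatic carbon para to a large group, gives a 1.0-fold lower number from compound 2 to compound 3 (0.01 log units; within the scatter), so this first single-place reading at this position shows no step that can be told from the scatter. With sulfamoyl held, the six-membered non-aromatic ring of carbon only in place of the six-membered aromatic ring of carbon only gives a 1.4-fold higher number from compound 1 to compound 3 (0.14 log units; within the scatter), so this second place, which compound 1 and compound 2 could not isolate, also shows no readable step. No measurement shown here bears on why either change leaves the number within the scatter.

Open, from the compounds shown here alone, is whether an amine or a carboxylic acid in place of sulfamoyl would give a step beyond the scatter. Also open, going by these compounds, is whether a methyl group on the non-aromatic ring would do so.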